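The source may hold more compounds than are shown below. What is called first, only, known or untested is meant among the compounds shown, and "the series" means these compounds.

Measured in the series:
- compound 1 `COc1cc(/C=C2\Cc3ccccc3/C(=C\c3ccc([N+](=O)[O-])cc3)C2=O)ccc1O` — 21000 nM
- compound 2 `COc1cc(/C=C2\Cc3ccccc3/C(=C\c3ccc([N+](=O)[O-])cc3)C2=O)cc(OC)c1OC` — > 400000 nM, a limit of the assay
- compound 3 `COc1cc(/C=C2/C(=O)/C(=C/c3ccc([N+](=O)[O-])cc3)c3ccccc32)cc(OC)c1OC` — > 400000 nM, a limit of the assay

Going by the values given here, in a functional assay on HPLF cells (Homo sapiens) for cytotoxicity (a lower number here means that less compound is tolerated, a higher number that more compound is tolerated), compound 1 gives 21000 nM, the only number obtained so far. For compound 2 this assay reports only a limit, > 400000 nM. For compound 3 likewise only a limit is reported, > 400000 nM. Among the compounds with values here, two of the three values therefore sit at the limit of > 400000 nM in this assay, at which 2 of the 3 values shown sit, and compound 1 is the sole compound with a measured concentration. Within the data shown here, no pair of measured compounds differs in a single place, so no measured step is available to gauge the effect of a change at the substituted ring.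

Compound 4 `O=C1/C(=C/c2ccc(O)cc2)Cc2ccccc2/C1=C\c1ccc([N+](=O)[O-])cc1` is the next compound to be measured. It differs from compound 1 by hydrogen in place of methoxy on an aromatic carbon. With no measured step of this kind in the series, the expectation rests on the value of compound 1 alone, and the step from compound 1 to compound 4 is expected to be small, a 1.2-fold higher number from compound 1 to compound 4 (0.08 log units; within the scatter), not clearly beyond the scatter in either direction. Compound 4 is accordingly estimated at 25000 nM in this assay, with a range from 8000 nM to 80000 nM.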

Compound 4, half-maximal cytotoxic concentration: 75000 nM
For compound 4 the middle estimate is 3.0-fold (0.48 log units) below the measured one; low and high end bracket the measured number.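

In this assay, going by these compounds alone, the change from 4-hydroxy-3-methoxyphenyl to 4-hydroxyphenyl gives the first measured step, a 3.6-fold higher number from compound 1 to compound 4 (0.55 log units; beyond the scatter), so the aromatic carbon ortho to the hydroxy group is a place where the read-out responds to a change of substituent. With the hydroxy group and the rest of the core of compound 1 unchanged, hydrogen in place of methoxy goes with more compound being tolerated, although this rests on a single pair and sets no trend for the series. Nothing measured in the data shown accounts for this step.

Within the data shown here, still open is whether the step is specific to methoxy, since the only comparison at this place is methoxy against hydrogen, and an ethoxy group, a chlorine atom or an amine there would show whether the read-out follows the size or the kind of the group. Also open is what the hydroxy group itself contributes, since no pair of compounds shown changes that group alone, and a replacement such as a carboxylic acid would address that question.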